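This account rests on a few compounds, and the source may have more. Where it says the series, first, only, none or still open, it means among the compounds named here.

Measured so far in a functional assay on A2780 cells (Homo sapiens) for cytotoxicity, read by MTT assay, with a stated time of 24 h; a higher number here means a weaker inhibitor, a lower number a stronger inhibitor:
compound 1, `CC[C@H](C)[C@@H](NC(=O)Cn1cc(C2=C(c3c[nH]c4ccccc34)C(=O)N(C)C2=O)c2ccccc21)C(=O)OC`, gives > 100000 nM, which is a limit of the assay.
compound 2, `COC(=O)[C@H](NC(=O)Cn1cc(C2=C(c3c[nH]c4ccccc34)C(=O)N(C)C2=O)c2ccccc21)[C@@H](C)O`, gives 21400 nM.

Compound 2 holds the only number shown in this assay; the other value is a limit. Compound 3 is `COC(=O)[C@@H](C)NC(=O)Cn1cc(C2=C(c3c[nH]c4ccccc34)C(=O)N(C)C2=O)c2ccccc21`, and it differs from compound 2 by methyl in place of 1-hydroxyethyl on a saturated chain carbon bound to an amide-type nitrogen and a carbonyl carbon. Among the compounds with values here, one measured step bears on this change: an at least 4.6-fold lower number from compound 1 to compound 2 (0.66 log units; beyond the scatter), in which a hydroxy group entered and the number fell beyond the scatter. Compound 3 drops the 1-hydroxyethyl altogether, and the step in this assay is therefore expected to run the other way, with a modest rise in the number, as a 2.6-fold higher number from compound 2 to compound 3 (0.41 log units; beyond the scatter). Compound 3 is estimated at 55000 nM in this assay, within a range from 15000 nM to 200000 nM, with a fair chance that only a limit is reported.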

Compound 3, half-maximal inhibitory concentration: 15800 nM
For compound 3 the middle estimate is 3.5-fold (0.54 log units) above the measured one; low and high end bracket the measured number.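

In this assay, the change from 1-hydroxyethyl to methyl comes out as a 1.4-fold lower number from compound 2 to compound 3 (0.13 log units; within the scatter), so the number seen with compound 2 does not depend on keeping the hydroxy group on this saturated chain carbon bound to an amide-type nitrogen and a carbonyl carbon. Methyl in place of sec-butyl at the same place gives an at least 6.3-fold lower number from compound 1 to compound 3 (0.80 log units; beyond the scatter), and among these three compounds only the sec-butyl compound stands apart from the other two. The value of compound 1 is a limit of the assay, not a number: the limit of > 100000 nM in this assay, at which 1 of the 3 values shown sits.

As far as these compounds go, it remains open how an amine or a longer chain on this carbon would read in this assay. From the compounds shown here alone, a carboxylic acid in place of the methyl ester is equally open.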